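A few compounds are considered here, and "the series" means these few. Any claim that something is new, unique, unknown or untested is made for them only; others in the source may bear on it.

Measured compounds:
compound 1 `COc1cc(/C=C2\CN(C)C/C(=C\c3ccc(Cl)cc3)C2=O)cc(OC)c1`, 5860 nM
compound 2 `COc1cc(/C=C2\CN(C)C/C(=C\c3ccc(Br)cc3)C2=O)cc(OC)c1`, 4270 nM
compound 3 `COc1cc(/C=C2\CN(C)C/C(=C\c3ccc(Cl)cc3)C2=O)cc(OC)c1OC`, 7200 nM

The three compounds were measured in a functional assay on THP-1 cells (Homo sapiens) for cytotoxicity, read by MTT assay, with a stated time of 24 h; a lower number here means a stronger inhibitor, a higher number a weaker inhibitor. Compound 1 gives 5860 nM, compound 2 gives 4270 nM, and compound 3 gives 7200 nM. Compound 2 differs from compound 1 by bromo in place of chloro on an aromatic carbon, a change that brought a 1.4-fold lower number from compound 1 to compound 2 (0.14 log units; within the scatter). Compound 3 differs from compound 1 by methoxy in place of hydrogen on an aromatic carbon, which brought a 1.2-fold higher number from compound 1 to compound 3 (0.09 log units; within the scatter).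

Compound 4 `COc1cc(/C=C2\CN(C)C/C(=C\c3ccc(Br)cc3)C2=O)cc(OC)c1OC` has not yet been measured. It differs from compound 3 by bromo in place of chloro on an aromatic carbon, the same change as between compound 1 and compound 2, and the surroundings of the place are the same in both pairs. The two cores differ as described for compound 1 and compound 3. Since that change gave a 1.4-fold lower number from compound 1 to compound 2 (0.14 log units; within the scatter), the step from compound 3 to compound 4 is expected to be of similar size, within the scatter, a 1.4-fold lower number from compound 3 to compound 4 (0.13 log units; within the scatter). Among the compounds with values here, compound 4 is therefore expected to give about 5300 nM in this assay, with a range estimated from 2600 nM to 11000 nM, resting on compound 3 at 7200 nM and on the single prior step of this kind.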

Compound 4, half-maximal inhibitory concentration: 5330 nM
Estimate against measurement, compound 4: 1.0-fold (0.00 log units) below; the measured number falls inside the stated range.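

In this assay, bromo in place of chloro on an aromatic carbon brought a 1.4-fold lower number from compound 3 to compound 4 (0.13 log units; within the scatter), and this step matches the earlier one: the same change on two cores in this assay, a 1.4-fold lower number (0.14 log units; within the scatter) from compound 1 to compound 2 and a 1.4-fold lower number (0.13 log units; within the scatter) from compound 3 to compound 4, 1.0-fold (0.01 log units) apart, within the scatter of two such steps. Methoxy in place of hydrogen on an aromatic carbon brought a 1.2-fold higher number from compound 2 to compound 4 (0.10 log units; within the scatter), and it too matches its earlier counterpart: the same change on two cores in this assay, a 1.2-fold higher number (0.09 log units; within the scatter) from compound 1 to compound 3 and a 1.2-fold higher number (0.10 log units; within the scatter) from compound 2 to compound 4, 1.0-fold (0.01 log units) apart, within the scatter of two such steps. Within the data shown here, both changes therefore read alike on the two cores, but since every one of these steps lies within the scatter, the four compounds show only that neither change shifted the number measurably on either core, not that either has a real effect of fixed size that carries from one core to another.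

The compounds shown leave open whether a group unlike these two halogens, such as a nitrile, an amine or a carboxylic acid, would give a step beyond the scatter in place of the chloro or bromo. They also leave open what a longer chain in place of the methyl on the nitrogen of the shared core would do.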